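Swapping the Aryl Group on a Triazole-Linked Cinnamic Acid

The source may hold more compounds than are shown below. What is called first, only, known or untested is meant among the compounds shown, and "the series" means these compounds.

Within the data shown here, compound 2, `COc1ccc(/C=C\C(=O)O)c(OCc2cn(-c3ccc(CO)cc3)nn2)c1CC=C(C)C`, is the only member of this small series with a number: in a functional assay on PC-3 cells (Homo sapiens) for cytotoxicity, read by MTT assay, with a stated time of 24 h (a higher number here means a weaker inhibitor, a lower number a stronger inhibitor), compound 2 gives 28300 nM, a weak result. Its companion compound 1, `COc1ccc(-n2cc(COc3c(/C=C\C(=O)O)ccc(OC)c3CC=C(C)C)nn2)cc1`, carries a related aryl group on the same ring nitrogen, but in this assay compound 1 gives "not determined" (no result reported), so nothing can be said about how the two compare.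

Compound 3, `COc1ccc(/C=C\C(=O)O)c(OCc2cn(-c3cccc([N+](=O)[O-])c3)nn2)c1CC=C(C)C`, is the next compound to be tested. It differs from compound 2 in one place: 3-nitrophenyl in place of 4-(hydroxymethyl)phenyl on an aromatic nitrogen. Among the measured compounds shown here, no measured pair in this set shows what such a swap does, so the expected step from compound 2 to compound 3 in this assay is small and without a clear direction, a 1.1-fold lower number from compound 2 to compound 3 (0.05 log units; within the scatter), within the usual scatter. On that basis compound 3 is estimated at 25000 nM, with a likely range from 8000 nM to 80000 nM.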

Compound 3, half-maximal inhibitory concentration: 42100 nM
For compound 3 the middle estimate is 1.7-fold (0.23 log units) below the measured one; low and high end bracket the measured number.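

Swapping 4-(hydroxymethyl)phenyl for 3-nitrophenyl on an aromatic nitrogen gives, in this assay, a 1.5-fold higher number from compound 2 to compound 3 (0.17 log units; within the scatter), the first step that can be read at this position. The swap removes the 1 hydrogen-bond donor of the leaving group and brings in a nitro-bearing ring, yet on this one pair the two compounds cannot be told apart. Nothing measured here speaks to why the two compounds read as they do.

Steps involving compound 1 cannot be read, as it has no result, so two compounds carry all that is known about this position. On these data alone, whether an aryl group bearing an amine or a carboxylic acid, or a simple alkyl chain in place of the aryl ring, would move the number beyond the scatter remains open.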